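Swapping the pyridyl group on the shared core

The compounds below may be only part of what the source reports. "The series", "measured", "known", "first", "only" and "open" are said of these compounds alone.

In an in vitro functional assay on HEK285-7 cells for antagonist activity at prostaglandin D2 receptor 2 (Homo sapiens), read by BRET and beta-arrestin recruitment (on this read-out lower numbers stand for smaller maximal responses and higher numbers for larger maximal responses), compound 2 `O=C(O)Cc1sc(C(c2ccc(F)cc2)c2ccc(F)cc2)nc1-c1ccnc(Cl)c1` gives 80%, the highest of the two numbers measured. Compound 1 `O=C(O)Cc1sc(CS(=O)(=O)c2ccc(Cl)cc2)nc1-c1ccc(Cl)cc1` gives 30% in this assay, a gap beyond the scatter. Compound 3 `Cc1cc(-c2nc(C(c3ccc(F)cc3)c3ccc(F)cc3)sc2CC(=O)O)cnc1N` carries 6-amino-5-methylpyridin-3-yl in place of 2-chloropyridin-4-yl on an aromatic carbon. Among the compounds with values here, no measured pair isolates this change, so nothing shows its size. A step from compound 2 to compound 3 of a number 10 percentage points lower from compound 2 to compound 3 (within the scatter) is expected, within or near the scatter and, if anything, downward. Compound 3 is estimated at 70%, between 45% and 95%.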

Compound 3, largest response reached (reported as efficacy), in percent of the reference or control that the assay uses: 80%
Compound 3: the middle estimate sits 10 percentage points below what was measured; the range from low to high includes it.
By their numbers in this assay, from the lowest: compound 1; then compounds 2 and 3 (each within the scatter of the next).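

At this aromatic carbon on the shared core, 6-amino-5-methylpyridin-3-yl in place of 2-chloropyridin-4-yl gives no change at the digits printed from compound 2 to compound 3 (within the scatter) in this assay. The position therefore tolerates this exchange of one pyridyl group for another, with the chlorine leaving and an amino and a methyl group entering, and the maximal response holds. Still open, going by these compounds, is whether the amino group or the methyl group alone would give the same response, and what a methoxy group or an unsubstituted pyridin-3-yl group would give here. No available measurement explains why the two groups match.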